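Removing a Ring Methyl in a Fused Sulfone Series

The source may hold more compounds than are shown below. What is called first, only, known or untested is meant among the compounds shown, and "the series" means these compounds.

Compound 1 `Cc1cc2c(cc1C(=O)N=C(N)N)S(=O)(=O)C(C)(C)C2(C)O` gives 17 nM in an assay on cells for inhibition of sodium/hydrogen exchanger (Oryctolagus cuniculus); on this read-out higher numbers stand for weaker inhibition and lower numbers for stronger inhibition.
Compound 2 `COC1(C)CS(=O)(=O)c2cc(C(=O)N=C(N)N)c(C)cc21` gives 40 nM in this assay.
Compound 3 `Cc1cc2c(cc1C(=O)N=C(N)N)S(=O)(=O)C(C)C2N` gives 56 nM in this assay.

Among these three, compound 1 has the lowest number, and its gaps to compound 2 and to compound 3 both lie beyond the usual scatter. Compound 4 `Cc1cc2c(cc1C(=O)N=C(N)N)S(=O)(=O)C(C)(C)C2O` differs from compound 1 in one place: hydrogen in place of methyl on a saturated ring carbon. Within the data shown here, no measured pair shows this exact change, so the size of the step can only be judged from the series as a whole. A modest weakening is expected, a step of a 1.6-fold higher number from compound 1 to compound 4 (0.22 log units; within the scatter) that may stay within or just beyond the scatter. Compound 4 is therefore expected to give about 28 nM in this assay, with a likely range from 10 nM to 70 nM.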

Compound 4, half-maximal inhibitory concentration: 28 nM
Compound 4: middle estimate and measured number agree at the digits printed; measured number inside the range.
By their numbers in this assay, from the lowest: compounds 1, 4, 2 and 3 (each within the scatter of the next, the first and the last beyond it).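

In this assay, among these compounds, compounds 1 and 4 form the first pair that differs in one place, and the step (a 1.6-fold higher number from compound 1 to compound 4 (0.22 log units; within the scatter)) lies within the scatter. The methyl on this saturated ring carbon is therefore not required for a number in this range, and this assay does not separate the two compounds. Nothing measured here offers an explanation for this result. Still open, going by these compounds, is whether a longer chain such as ethyl, or a fluorine atom, on this same carbon would leave the number within the scatter.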